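This account rests on a few compounds, and the source may have more. Where it says the series, first, only, none or still open, it means among the compounds named here.

Working notes on the series, cytotoxicity arm. Compound 1 `Cc1ccc(-c2nnc(N3CCN(C(=O)CN4CCN(c5cccc(Cl)c5)CC4)CC3)nc2-c2ccc(C)cc2)cc1` in an ADME assay on NIH3T3 cells (Mus musculus) for cytotoxicity, read by MTT assay, with a stated time of 24 h (on this read-out higher numbers stand for weaker inhibition and lower numbers for stronger inhibition), gives 859000 nM. Compound 2 `COc1ccc(N2CCN(CC(=O)N3CCN(c4nnc(-c5ccc(C)cc5)c(-c5ccc(C)cc5)n4)CC3)CC2)cc1` in this assay gives 116000 nM. The change between them, (4-methoxyphenyl in place of 3-chlorophenyl on an amine nitrogen in a ring), produced a 7.4-fold lower number from compound 1 to compound 2 (0.87 log units; beyond the scatter). Compound 3 `COc1ccc(-c2nnc(N3CCN(C(=O)CN4CCN(c5cccc(Cl)c5)CC4)CC3)nc2-c2ccc(OC)cc2)cc1` carries a different core; how the core of compound 3 differs from the core of compound 1 is not broken down here. For compound 3 in this assay only a limit is known, > 814000 nM, which is the limit of > 814000 nM in this assay, at which 1 of the 3 values shown sits. Compound 4 `COc1ccc(-c2nnc(N3CCN(C(=O)CN4CCN(c5ccc(OC)cc5)CC4)CC3)nc2-c2ccc(OC)cc2)cc1` differs from compound 3 by 4-methoxyphenyl in place of 3-chlorophenyl on an amine nitrogen in a ring, the same change as from compound 1 to compound 2, at a place described in the same words. Among the measured compounds shown here, from compound 3 to compound 4 a step of about an at least 2.3-fold lower number from compound 3 to compound 4 (0.36 log units; beyond the scatter) is expected, resting on a 7.4-fold lower number from compound 1 to compound 2 (0.87 log units; beyond the scatter) as the only measured instance of this change. Compound 4 is accordingly expected near 350000 nM, plausibly between 90000 nM and 1200000 nM, with a fair chance that this assay again reports only a limit.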

Compound 4, half-maximal inhibitory concentration: > 821000 nM
Compound 4: a limit, no number (the forecaster's own chance of this, stated with the estimate: 35%); middle value at least 2.3-fold (0.37 log units) from the limit.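

Compound 3 and compound 4 both stand only as limits in this assay, so the step between them cannot be read. From the compounds shown here alone, whether 4-methoxyphenyl in place of 3-chlorophenyl on the core of compound 3 repeats a 7.4-fold lower number from compound 1 to compound 2 (0.87 log units; beyond the scatter) stays open.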